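The source may hold more compounds than are shown below. What is called first, only, known or untested is meant among the compounds shown, and "the series" means these compounds.

Compound 1 `c1ccc(-c2nc[nH]n2)c(NCC2=NCCN2)c1`: in an in vitro functional assay on cells (Fibroblast) for agonist activity at Alpha-1D adrenergic receptor (Homo sapiens) (on this read-out higher numbers stand for an effect only at larger amounts of compound and lower numbers for an effect already at smaller amounts), compound 1 gives 3.98 nM.
Compound 2 `Cn1ccc(-c2ccccc2NCC2=NCCN2)n1`: in this assay compound 2 gives 15.9 nM.
Compound 3 `Cn1cc(-c2ccccc2NCC2=NCCN2)cn1`: in this assay compound 3 gives only a limit, < 100000 nM, so no number is known for it.

Compound 3 stands apart: of the three values, one is a limit (the limit of < 100000 nM in this assay, at which 1 of the 3 values shown sits), and it is this one, so the steps a step that the limit leaves unreadable from compound 1 to compound 3 and a step that the limit leaves unreadable from compound 2 to compound 3 cannot be sized. Compound 4 `Cn1ccnc1-c1ccccc1NCC1=NCCN1` differs from compound 3 by 1-methyl-1H-imidazol-2-yl in place of 1-methyl-1H-pyrazol-4-yl on an aromatic carbon. Going by the values given here, the one readable step, a 4.0-fold higher number from compound 1 to compound 2 (0.60 log units; beyond the scatter), shows that exchanging one five-membered ring for another can shift this assay modestly. With compound 3 known only as a limit, the direction for compound 4 is open, but a value nearer those of compound 1 and compound 2 is expected. The expected step is a step that the limit leaves unreadable from compound 3 to compound 4. Compound 4 is estimated at 30 nM, with a range from 5 nM to 300 nM.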

Compound 4, half-maximal effective concentration: 200 nM
For compound 4 the middle estimate is 6.7-fold (0.82 log units) below the measured one, within the range that was stated.
By their numbers in this assay, from the lowest: compound 1; then compound 2; then compound 4.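

Rings made of the same atoms, joined differently, are not interchangeable at this position: in this assay, 1-methyl-1H-imidazol-2-yl in place of 1-methyl-1H-pyrazol-3-yl gives a 13-fold higher number from compound 2 to compound 4 (1.10 log units; beyond the scatter). Going by these compounds alone, in place of 1H-1,2,4-triazol-3-yl, the same ring gives a 50-fold higher number from compound 1 to compound 4 (1.70 log units; beyond the scatter), the largest readable step so far. The comparison with compound 3 cannot be read, since compound 3 is known only as a limit: the limit of < 100000 nM in this assay, at which 1 of the 4 values shown sits.

Going by these compounds, whether this position needs a five-membered aromatic ring at all remains open. A simple amine or a carboxylic acid on this aromatic carbon would address that question.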